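Methylating the ring nitrogen of compound 1

The source may report more compounds than this note shows. Statements on the series, on what has been measured and on what is new or still open speak of the compounds shown alone.

Measured in a functional assay on A2780 cells (Homo sapiens) for antiproliferative activity, read by MTT assay, with a stated time of 48 h; a higher number here means a weaker inhibitor, a lower number a stronger inhibitor:
compound 1 `COc1ccc2c(/C=C/C(=O)c3cc(OC)c(OC)c(SC)c3)c[nH]c2c1`: 139 nM
compound 2 `COc1ccc2c(/C=C/C(=O)c3cc(OC)c(OC)c([N+](=O)[O-])c3)c[nH]c2c1`: 742 nM
compound 3 `COc1cc(C(=O)/C=C/c2c[nH]c3ccccc23)cc(SC)c1OC`: 169 nM

Within this small set, compound 1 shares the low end of the range with compound 3, and the two cannot be told apart. Compound 2 stands clearly apart from compound 1, with a 5.3-fold higher number from compound 1 to compound 2 (0.73 log units; beyond the scatter) as the measured step.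

The next compound to be tested is compound 4 `COc1ccc2c(/C=C/C(=O)c3cc(OC)c(OC)c(SC)c3)cn(C)c2c1`, which differs from compound 1 at one place: methyl in place of hydrogen on an aromatic nitrogen. For the measured compounds named here, no measured step touches this nitrogen, so the data offer only indirect guidance. Replacing methoxy with hydrogen on an aromatic carbon gave a 1.2-fold higher number from compound 1 to compound 3 (0.08 log units; within the scatter) as its step, so that edit to compound 1 left the number unchanged within the scatter. Replacing methylsulfanyl with nitro gave the larger 5.3-fold higher number from compound 1 to compound 2 (0.73 log units; beyond the scatter) as its step, which shows that the numbers in this set can move, but that change lies at a different place.

On this limited evidence, no shift beyond the scatter is expected, and no direction is favoured. The expected change is a 1.1-fold higher number from compound 1 to compound 4 (0.03 log units; within the scatter) as an estimate. Compound 4 is expected to read about 150 nM in this assay, with an estimated range from 50 nM to 450 nM as the likely span.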

Compound 4, half-maximal inhibitory concentration: 145 nM
Compound 4: middle estimate off by 1.0-fold (0.01 log units), on the high side; measured number inside the range.
By their numbers in this assay, from the lowest: compounds 1, 4 and 3 (each within the scatter of the next); then compound 2.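

In this assay, the aromatic nitrogen of the five-membered ring now has a measured step of its own: methyl in place of hydrogen gave a 1.0-fold higher number from compound 1 to compound 4 (0.02 log units; within the scatter). For the compounds shown here, all the earlier compounds carry hydrogen on this nitrogen, so they could not show what this result shows: in the setting of compound 1, the hydrogen there can give way to a methyl with no change beyond the scatter, and the nitrogen hydrogen is not required for a number at this level. The data on hand offer nothing that accounts for this lack of change, so it stands as an observation without an explanation.

What the compounds shown leave open is whether this holds only for the single carbon of a methyl, or also for something larger on the same nitrogen, such as a longer chain, a benzyl group, or a chain ending in an amine or a carboxylic acid. On these data alone, it also remains open whether the same methyl would leave the number just as unchanged on compound 2 or compound 3, whose other substituents differ from those of compound 1.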